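A few compounds are considered here, and "the series" means these few. Any claim that something is new, unique, unknown or untested is made for them only; others in the source may bear on it.

Compounds measured so far:

compound 1, `Cc1cc(CCC(=O)O)ccc1-c1noc(-c2ccc(OC(C)C)c(C(F)(F)F)c2)n1`; in a functional assay on CHO cells with sphingosine 1-phosphate receptor 4 (Homo sapiens) as the target, read by GTPgammaS binding (on this read-out lower numbers stand for an effect already at smaller amounts and higher numbers for an effect only at larger amounts of compound), compound 1 gives a value at the limit of the assay, > 10000 nM.
compound 2, `Cc1cc(CCC(=O)O)ccc1-c1noc(-c2ccc(OC(C)C)c(Cl)c2)n1`; in this assay compound 2 gives a value at the limit of the assay, > 10000 nM.
compound 3, `Cc1cc(-c2nc(-c3ccc(CCC(=O)O)cc3C)no2)ccc1OC(C)C`; in this assay compound 3 gives a value at the limit of the assay, > 10000 nM.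

Compound 3 stands where all three measured compounds stand: at a limit, not at a number, and the same holds for the two others shown with it, as the limit of > 10000 nM in this assay, at which 3 of the 3 values shown sit, records. The step from compound 1 to compound 2, a step that the two limits leave unreadable from compound 1 to compound 2, from compound 1 to compound 3, a step that the two limits leave unreadable from compound 1 to compound 3, and from compound 2 to compound 3, a step that the two limits leave unreadable from compound 2 to compound 3, are all unreadable for this reason; exchanging trifluoromethyl, chloro and methyl at this position moves nothing that the assay can resolve.

Compound 4, `Cc1cc(CCC(=O)O)ccc1-c1noc(-c2ccc(OC(C)C)c(Br)c2)n1`, differs from compound 3 by bromo in place of methyl on an aromatic carbon. The three steps that bear on this position all sit between limits and give no size, so no step beyond the scatter in this assay is expected in either direction; compound 4 is expected to stay at the limit, as compound 3 does with > 10000 nM. The estimated step from compound 3 to compound 4 is a step that the limit leaves unreadable from compound 3 to compound 4, and compound 4 is estimated at 15000 nM, within 8000 nM to 30000 nM.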

Compound 4, half-maximal effective concentration: > 10000 nM
Compound 4: no number, only a limit (the forecaster's own chance of this, stated with the estimate: 85%); the middle value is on the limit's open side.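

The steps to compound 4 from compound 1, compound 2 and compound 3 cannot be read, since all four compounds sit at the same limit: the limit of > 10000 nM in this assay, at which 4 of the 4 values shown sit.

The compounds shown leave open whether any group at this position, ortho to the isopropoxy group, gives a measurable value in this assay, and how far each compound lies beyond the limit.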